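Chain-end aryl replacement in an EP4 ligand series

This account rests on a few compounds, and the source may have more. Where it says the series, first, only, none or still open, it means among the compounds named here.

Measured compounds:
compound 1 `O=C(O)/C=C/c1ccc(Cn2ccnc2)cc1OCCCOc1ccccc1`; in an assay on CHO cells for displacement of a labelled ligand from prostaglandin E2 receptor EP4 subtype (Mus musculus), read by scintillation counting (on this read-out higher numbers stand for weaker inhibition and lower numbers for stronger inhibition), compound 1 gives > 10000 nM, a limit.
compound 2 `O=C(O)/C=C/c1ccc(Cn2ccnc2)cc1OCCCCOc1ccccc1`; in this assay compound 2 gives > 10000 nM, a limit.

Compound 2 therefore stands only at a limit of this assay. The step that the two limits leave unreadable from compound 1 to compound 2 is unreadable, since the limit of > 10000 nM in this assay, at which 2 of the 2 values shown sit, holds both values. Compound 3 `O=C(O)/C=C/c1ccc(Cn2ccnc2)cc1OCCc1ccc2ccccc2c1` introduces (naphthalen-2-yl in place of 2-phenoxyethyl on a saturated chain carbon, two bonds along the chain from an oxygen on an aromatic ring). For the measured compounds named here, no measured step reads on this change, so neither direction nor size beyond the scatter can be taken from the data. Compound 3 is expected to stay near the limit, estimated at 10000 nM within 2000 nM to 30000 nM. The expected step is a number no higher from compound 2 to compound 3 (the limit leaves the size open).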

Compound 3, inhibition constant: 2200 nM
The estimate for compound 3 lay 4.5-fold (0.66 log units) above the measured number; low and high end bracket the measured number.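

Naphthalen-2-yl at this place, on a saturated chain carbon, two bonds along the chain from an oxygen on an aromatic ring, gives the only number in this assay that is not a limit, with an at least 4.5-fold lower number from compound 2 to compound 3 (0.65 log units; beyond the scatter) and an at least 4.5-fold lower number from compound 1 to compound 3 (0.65 log units; beyond the scatter). For the compounds shown here, the earlier phenoxy-ended chains gave no readable step, so this is the first change at this position that moves the read-out. Both steps are minimum sizes only, because their starting values are limits: the limit of > 10000 nM in this assay, at which 2 of the 3 values shown sit.

On these data alone, whether the step follows from the two fused aromatic rings or from the absent chain oxygen stays open. Also open, as far as these compounds go, is how a plain phenyl or a naphthalen-1-yl would read at the same place.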